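Moving the small ring one carbon further from the amine

The source may report more compounds than this note shows. Statements on the series, on what has been measured and on what is new or still open speak of the compounds shown alone.

Compound 1 `CCN(Cc1c(C(F)(F)F)nc2n(-c3c(C)cc(C)cc3C)c(Cl)cn12)CC1CC1` gives 9 nM in an assay on cells for displacement of a labelled ligand from corticotropin-releasing factor receptor 1 (Homo sapiens), with a stated time of 100 min; on this read-out lower numbers stand for stronger inhibition and higher numbers for weaker inhibition.
Compound 2 `CCCN(CCC(F)(F)F)Cc1c(C(F)(F)F)nc2n(-c3c(C)cc(C)cc3C)c(Cl)cn12` gives 12 nM in this assay.
Compound 3 `CCN(Cc1c(C(F)(F)F)nc2n(-c3c(C)cc(C)cc3C)c(Cl)cn12)CC1CCC1` gives 16 nM in this assay.

Among these three, compound 3 shows the highest number, yet its distances to the other two are small: a 1.8-fold higher number from compound 1 to compound 3 (0.25 log units; within the scatter) and a 1.3-fold higher number from compound 2 to compound 3 (0.12 log units; within the scatter). Compound 4 `CCN(CCC1CC1)Cc1c(C(F)(F)F)nc2n(-c3c(C)cc(C)cc3C)c(Cl)cn12` differs from compound 3 by cyclopropylmethyl in place of cyclobutyl on a saturated chain carbon bound to an amine nitrogen. The measured steps that touch the same part of the molecule, the groups on the amine nitrogen, are a 1.8-fold higher number from compound 1 to compound 3 (0.25 log units; within the scatter), a 1.3-fold higher number from compound 1 to compound 2 (0.12 log units; within the scatter) and a 1.3-fold higher number from compound 2 to compound 3 (0.12 log units; within the scatter); none of them leaves the scatter, and the first of them is the reverse of the change now considered, apart from the ring being placed one carbon further out along the chain. Every change tried so far in this part of the molecule has left the number roughly where it was, so no step beyond the scatter in this assay is expected here either. Compound 4 is estimated at 13 nM, with a range from 5 nM to 35 nM, which corresponds to an expected step of a 1.2-fold lower number from compound 3 to compound 4 (0.09 log units; within the scatter).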

Compound 4, inhibition constant: 13 nM
Estimate against measurement, compound 4: no gap at the digits printed, within the range that was stated.
By their numbers in this assay, from the lowest: compounds 1, 2, 4 and 3 (each within the scatter of the next).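

In this assay, the same four carbons can sit on the saturated chain carbon bound to the amine nitrogen as cyclobutyl or as cyclopropylmethyl without leaving the scatter (a 1.2-fold lower number from compound 3 to compound 4 (0.09 log units; within the scatter)). Setting the three-membered ring one carbon further from the amine, as 2-cyclopropylethyl, also stays within the scatter (a 1.4-fold higher number from compound 1 to compound 4 (0.16 log units; within the scatter)), and so does the step from the fluorinated amine of the second compound (a 1.1-fold higher number from compound 2 to compound 4 (0.03 log units; within the scatter)), so this position has now taken four different pairs of amine groups with no step beyond the scatter. Nothing available explains why the number stays so flat here.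

As far as these compounds go, whether the same holds for a carboxylic acid or a hydroxyl group at the end of this chain remains open. So does the effect of a much longer chain, such as hexyl, or of a morpholine ring in place of the open amine.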